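The source may hold more compounds than are shown below. What is called first, only, known or untested is meant among the compounds shown, and "the series" means these compounds.

The measured compounds:
Compound 1, `COc1ccc(-n2nc(C(=O)Nc3ccc(Oc4ccnc5cc(OCCCN6CCC(C)CC6)c(OC)cc45)c(F)c3)c(C)cc2=O)cc1`, in a functional assay on MKN-45 cells (Homo sapiens) for inhibition, read by MTT assay, with a stated time of 72 h (a lower number here means a stronger inhibitor, a higher number a weaker inhibitor), gives 400 nM.
Compound 2, `COc1cc2c(Oc3ccc(NC(=O)c4nn(-c5ccc(Cl)cc5)c(=O)cc4C)cc3F)ccnc2cc1OCCCN1CCCC1`, in this assay gives 150 nM.
Compound 3, `COc1cc2c(Oc3ccc(NC(=O)c4nn(-c5ccc(Cl)cc5)c(=O)cc4C)cc3F)ccnc2cc1OCCCN1CCCCC1`, in this assay gives 230 nM.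

Among these three numbers compound 3 stands second highest. Its nearest neighbour is compound 2, and its furthest is compound 1, but both gaps lie within the scatter of repeated measurements, so the three compounds cannot be ordered against one another on this evidence. Within the data shown here, the only pair that differs in a single place is compound 2 and compound 3, and that step, a 1.5-fold higher number from compound 2 to compound 3 (0.19 log units; within the scatter), is itself within the scatter.

Compound 4, `COc1cc2c(Oc3ccc(NC(=O)c4nn(-c5ccc(Cl)cc5)c(=O)cc4C)cc3F)ccnc2cc1OCCCN1CCC(C)CC1`, differs from compound 3 by methyl in place of hydrogen on a saturated ring carbon. Among the measured compounds shown here, compound 1 also carries a 4-methylpiperidin-1-yl, yet it differs from compound 3 in a second place as well, so no single step links it to compound 3; its number and that of compound 3 sit within the scatter of each other. For the measured compounds named here, the one measured step at the basic ring, the change from pyrrolidin-1-yl to piperidin-1-yl, moved the number by an amount inside the scatter. On that basis, the step from compound 3 to compound 4 is expected to be a 1.1-fold higher number from compound 3 to compound 4 (0.04 log units; within the scatter), which is no change beyond the scatter. Compound 4 is therefore estimated to give 250 nM in this assay, with a range from 110 nM to 550 nM.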

Compound 4, half-maximal inhibitory concentration: 150 nM
For compound 4 the middle estimate is 1.7-fold (0.22 log units) above the measured one; the range from low to high includes it.
By their numbers in this assay, from the lowest: compounds 2, 4, 3 and 1 (each within the scatter of the next, the first and the last beyond it).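

Adding the methyl gives a 1.5-fold lower number from compound 3 to compound 4 (0.19 log units; within the scatter) in this assay and so does not separate 4-methylpiperidin-1-yl from piperidin-1-yl at this saturated ring carbon, three ring bonds from the ring nitrogen. The comparison with the smaller ring reads the same way, with no change at the digits printed from compound 2 to compound 4 (within the scatter) for 4-methylpiperidin-1-yl in place of pyrrolidin-1-yl, so all three basic rings remain indistinguishable in this assay. Compound 4 also gives compound 1 its first single-place link, and with 4-methylpiperidin-1-yl held constant, the change to chloro in place of methoxy on an aromatic carbon produces a 2.7-fold lower number from compound 1 to compound 4 (0.43 log units; beyond the scatter) as a modest step, the only one shown here that lies beyond the scatter. Nothing available accounts for either the flat result at the ring or the step at the aromatic carbon.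

The compounds shown do not tell whether a hydroxy group or an ethyl group on the same ring carbon, or morpholin-4-yl in place of the whole ring, would stay within the scatter. They also leave open whether the step from methoxy to chloro holds with pyrrolidin-1-yl or piperidin-1-yl, and how fluoro or trifluoromethyl would compare on that aromatic carbon.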